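The compounds below may be only part of what the source reports. "The series", "measured", "known", "first", "only" and "open" are said of these compounds alone.

Measured in an ADME assay on L6 cells (Rattus norvegicus) for cytotoxicity, read by fluorescence and resazurin assay, with a stated time of 72 h; a lower number here means that less compound is tolerated, a higher number that more compound is tolerated:
- compound 1 `CC(C)c1ccc(-c2c[nH]cc2C(c2ccc(Cl)cc2Cl)n2ccnc2)cc1` gives 12700 nM
- compound 2 `Clc1ccc(C(c2c[nH]cc2-c2ccc(Cl)cc2-c2ccccc2)n2ccnc2)cc1` gives 14900 nM
- compound 3 `Clc1ccc(C(c2c[nH]cc2-c2ccc3ccccc3c2)n2ccnc2)c(Cl)c1` gives 6540 nM

Compound 1 stands second highest of these three numbers, but it lies within the scatter of both compound 2 and compound 3. Compound 4 `CSc1ccc(-c2c[nH]cc2C(c2ccc(Cl)cc2Cl)n2ccnc2)cc1` has not yet been measured. It carries methylsulfanyl in place of isopropyl on an aromatic carbon, para to a large group (methylsulfanyl in place of isopropyl on an aromatic carbon). Among the measured compounds shown here, no measured pair shows this change directly, so no step beyond the scatter is expected. The expected step is small, a 1.1-fold lower number from compound 1 to compound 4 (0.02 log units; within the scatter) in this estimate. For compound 4 the estimated value is 12000 nM as the middle of an expected range, which runs from 6000 nM to 24000 nM in all.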

Compound 4, half-maximal cytotoxic concentration: 7220 nM
Beside the measured number, compound 4's estimate is 1.7-fold (0.22 log units) above it; low and high end bracket the measured number.
By their numbers in this assay, from the lowest: compounds 3, 4, 1 and 2 (each within the scatter of the next, the first and the last beyond it).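

In this assay, among the compounds shown here, methylsulfanyl in place of isopropyl on an aromatic carbon gives a 1.8-fold lower number from compound 1 to compound 4 (0.25 log units; within the scatter) and so offers the first direct reading of this change. At this position, para to a large group, the exchange brings in sulfur and a hydrogen-bond acceptor without a step beyond the scatter. Nothing available explains the size of this step.

On these data alone, whether an amine, a carboxylic acid or a longer chain at this position would move the number beyond the scatter remains open. So does whether methylsulfanyl would behave the same way on a different core.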